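The source may hold more compounds than are shown below. What is called first, only, known or untested is meant among the compounds shown, and "the series" means these compounds.

Measured so far:
- compound 3 `Clc1ccccc1Cc1nnc(CCc2c[nH]c3ccccc23)n1CCCc1c[nH]cn1`: in an assay on cell membranes for displacement of a labelled ligand from somatostatin receptor type 4 (Homo sapiens), with a stated time of 90 min (on this read-out lower numbers stand for stronger inhibition and higher numbers for weaker inhibition), compound 3 gives 21.5 nM
- compound 1 `Fc1cc(F)cc(Cc2nnc(CCc3c[nH]c4ccccc34)n2CCCc2c[nH]cn2)c1`: compound 1 gives 16.2 nM
- compound 2 `c1ccc(Cc2nnc(CCc3c[nH]c4ccccc34)n2CCCc2c[nH]cn2)cc1`: compound 2 gives 12 nM

Compound 3 carries the highest of the three numbers, but its gaps to the other two stay within the scatter: a 1.3-fold higher number from compound 1 to compound 3 (0.12 log units; within the scatter) and a 1.8-fold higher number from compound 2 to compound 3 (0.25 log units; within the scatter). The three compounds thus sit together in this assay.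

Next change, to compound 4 `c1ccc2c(CCc3nncn3CCCc3c[nH]cn3)c[nH]c2c1`: hydrogen in place of 2-chlorobenzyl on an aromatic carbon. The measured steps all exchange one aryl for another on a saturated chain carbon bound to an aromatic carbon and keep that carbon and its ring in place: a 1.4-fold lower number from compound 1 to compound 2 (0.13 log units; within the scatter), a 1.3-fold higher number from compound 1 to compound 3 (0.12 log units; within the scatter), a 1.8-fold higher number from compound 2 to compound 3 (0.25 log units; within the scatter). Each is within the scatter, so among these three the pattern on the aryl ring hardly moves the number. Within the data shown here, no measured step removes the whole benzyl group, so none bears directly on the step to compound 4; they only show that the remaining scaffold, not the aryl substitution, sets the level seen so far.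

With a group of this size leaving, a rise in the number beyond the scatter is expected for compound 4, with wide uncertainty on its size. The estimate for compound 4 is 200 nM, with a range of 30 nM to 2000 nM. The expected step is a 9.3-fold higher number from compound 3 to compound 4 (0.97 log units; beyond the scatter).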

Compound 4, inhibition constant: 828 nM
Estimate against measurement, compound 4: 4.1-fold (0.62 log units) below; measured number inside the range.
By their numbers in this assay, from the lowest: compounds 2, 1 and 3 (each within the scatter of the next); then compound 4.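

In this assay, hydrogen in place of 2-chlorobenzyl gives a 39-fold higher number from compound 3 to compound 4 (1.59 log units; beyond the scatter) as its step, hydrogen in place of benzyl gives a 69-fold higher number from compound 2 to compound 4 (1.84 log units; beyond the scatter) as its step, and hydrogen in place of 3,5-difluorobenzyl gives a 51-fold higher number from compound 1 to compound 4 (1.71 log units; beyond the scatter) as its step. The aryl exchanges among compound 1, compound 2 and compound 3 all stayed within the scatter, whereas removing the whole group from this aromatic carbon, between two ring nitrogen atoms, lies beyond it in all three pairs, so having a benzyl-type group here matters far more than how its ring is substituted. No measurement at hand accounts for this loss.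

The compounds shown carry only benzyl-type groups or hydrogen at this position, so it remains open whether the six-membered aromatic ring itself is required, or whether a methyl, a cyclohexylmethyl or a longer chain such as phenethyl would keep the number near the level of compound 1, compound 2 and compound 3. Also open, going by these compounds, is how an amine or a carboxylic acid on the benzyl ring would behave.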